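Adding one fluoro to compound 3

The source may report more compounds than this note shows. Statements on the series, on what has been measured and on what is new or still open speak of the compounds shown alone.

Values so far in a physicochemical assay for lipophilicity, read by HPLC, at pH 7.5; a higher number here means a more lipophilic compound, a lower number a more polar compound
compound 1 `CC[C@@H](Nc1c(C#N)c(-c2ccc(-c3ccccc3F)cc2)nc2cnccc12)C(N)=O` gives 2.7
compound 2 `CC[C@@H](Nc1c(C#N)c(-c2ccc(-c3ncccc3C)cc2)nc2cnccc12)C(N)=O` gives 2
compound 3 `CC[C@@H](Nc1c(C#N)c(-c2ccc(-c3cccc(C)c3)cc2)nc2cnccc12)C(N)=O` gives 3

The steps are a number 0.30 log units higher from compound 1 to compound 3 (within the scatter) and a number 1.00 log units higher from compound 2 to compound 3 (beyond the scatter) so compound 3 shares the top of this small set with compound 1 and stands clear of compound 2. The next change fluoro in place of hydrogen on an aromatic carbon is fluoro in place of hydrogen on an aromatic carbon, ortho to a large group and ortho to a methyl group, and it turns compound 3 into compound 4 `CC[C@@H](Nc1c(C#N)c(-c2ccc(-c3cccc(C)c3F)cc2)nc2cnccc12)C(N)=O` with nothing else altered. Within the data shown here, no measured step makes this change alone. The nearest guide is compound 1, which carries a fluoro and shows a number 0.30 log units higher from compound 1 to compound 3 (within the scatter) against the methyl-bearing ring. In this assay the expected change is only a number 0.10 log units higher from compound 3 to compound 4 (within the scatter) and no larger. Compound 4 is estimated at 3.1 with an expected range from 2.7 to 3.5 for repeated readings.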

Compound 4, distribution coefficient: 3
Compound 4: middle estimate off by 0.10 log units, on the high side; low and high end bracket the measured number.
By their numbers in this assay, from the lowest: compound 2; then compounds 1, 3 and 4 (each within the scatter of the next).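

In this assay fluoro in place of hydrogen, ortho to a large group and ortho to a methyl group, gives no readable shift (no change at the digits printed from compound 3 to compound 4 (within the scatter)). Methyl in place of hydrogen on the fluoro-bearing ring also stays inside the noise (a number 0.30 log units higher from compound 1 to compound 4 (within the scatter)), whereas 2-fluoro-3-methylphenyl in place of 3-methylpyridin-2-yl gives the one clear step (a number 1.00 log units higher from compound 2 to compound 4 (beyond the scatter)). Nothing available here explains these readings. Still open, from the compounds shown here alone, is how a chloro, a methoxy or an amine at this same position would read.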